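The compounds below may be only part of what the source reports. "The series", "measured", "known", "first", "only" and "open" are said of these compounds alone.

Compound 1 `O=C(/C=C/c1ccc(N2CCCC2)cc1)c1ccc([N+](=O)[O-])cc1`: 77.6%
Compound 2 `O=C(/C=C/c1ccc(F)cc1)c1ccc(O)cc1O`: 56.7%
Compound 3 `O=C(/C=C/c1ccc(N2CCCC2)cc1)c1ccc(O)cc1O`: 64.4%

All three were tested in an assay on isolated protein for inhibition of DNA topoisomerase 1 (Homo sapiens), tested at 20 uM; a lower number here means a weaker effect, a higher number a stronger effect of the compound at the concentration tested. Compound 2 sits at the low end of these numbers: the step of a number 7.7 percentage points higher from compound 2 to compound 3 (within the scatter) lies within the scatter, so compound 2 and compound 3 cannot be told apart, while compound 1 is higher by an amount beyond the scatter. Compound 4 `COc1cc(O)ccc1C(=O)/C=C/c1ccc(F)cc1` differs from compound 2 by methyl in place of hydrogen on an oxygen on an aromatic ring. No measured step involves this change; the single step shown, from compound 2 to compound 3, exchanges a different group and says nothing about a change from hydroxy to methoxy. With nothing to lean on, the value is expected to stay near that of compound 2, an expected step of a number 1.7 percentage points lower from compound 2 to compound 4 (within the scatter). Compound 4 is therefore estimated at 55%, within 38% to 72%.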

Compound 4, a percentage reported as inhibition, at one concentration (the size of the read-out at that concentration, not a potency): 61.6%
Compound 4: the middle estimate sits 6.6 percentage points below what was measured; measured number inside the range.
By their numbers in this assay, from the lowest: compounds 2, 4 and 3 (each within the scatter of the next); then compound 1.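

Putting methyl in place of hydrogen on this oxygen gives a number 4.9 percentage points higher from compound 2 to compound 4 (within the scatter) in this assay. The two compounds cannot be told apart, so at this position the hydrogen of the hydroxy is not needed for the effect seen at this concentration. Nothing available offers an explanation for this result.

From the compounds shown here alone, it remains open whether a longer chain on this oxygen, such as ethyl or benzyl, or an amine in place of the hydroxy, would fit equally well. Going by these compounds, it is also open whether hydroxy to methoxy reads the same when pyrrolidin-1-yl replaces fluoro.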